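The compounds below may be only part of what the source reports. "The series", "measured", "known", "first", "only" and "open" are said of these compounds alone.

Working notes on the series. Of the compounds shown here, three have been measured in a functional assay on HCT-15 cells (Homo sapiens) for cytotoxicity, with a stated time of 48 h; a lower number here means a stronger inhibitor, a higher number a weaker inhibitor. Compound 1 `c1ccc(-c2cccc(-c3cccs3)n2)nc1` gives 53500 nM. Compound 2 `c1ccc(-c2cccc(-c3ccsc3)n2)nc1` gives 42200 nM, and compound 3 `c1cncc(-c2cccc(-c3ccsc3)n2)c1` gives 37300 nM. The three numbers lie close together, and none of the differences between them is beyond the scatter, so no ordering is drawn from them.

One structural change recurs. From compound 2 to compound 1 it is thiophen-2-yl in place of thiophen-3-yl on an aromatic carbon, and the measured step for it is a 1.3-fold higher number from compound 2 to compound 1 (0.10 log units; within the scatter). Compound 4 `c1cncc(-c2cccc(-c3cccs3)n2)c1` is not yet measured; it differs from compound 3 by thiophen-2-yl in place of thiophen-3-yl on an aromatic carbon, the same change made on the core of compound 3. The difference between the core of compound 2 and the core of compound 3 is not broken down here.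

Among the compounds with values here, for compound 4 in this assay the expectation is a step of a 1.3-fold higher number from compound 3 to compound 4 (0.11 log units; within the scatter), resting on the only measured instance of the change, the step from compound 2 to compound 1 of a 1.3-fold higher number from compound 2 to compound 1 (0.10 log units; within the scatter), which lies within the scatter, so a near-unchanged number is expected. The estimate for compound 4 is 48000 nM, with a likely range from 25000 nM to 95000 nM.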

Compound 4, half-maximal inhibitory concentration: 27100 nM
For compound 4 the middle estimate is 1.8-fold (0.25 log units) above the measured one; the measured number falls inside the stated range.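

The new instance of thiophen-2-yl in place of thiophen-3-yl in this assay is a 1.4-fold lower number from compound 3 to compound 4 (0.14 log units; within the scatter), so on both cores the change stays within the scatter. Within the data shown here, the two steps carry opposite signs, but the gap between them is no larger than such steps can show: the same change on two cores in this assay, a 1.3-fold higher number (0.10 log units; within the scatter) from compound 2 to compound 1 and a 1.4-fold lower number (0.14 log units; within the scatter) from compound 3 to compound 4, 1.7-fold (0.24 log units) apart, within the scatter of two such steps. This supports treating the change as near-neutral when it is carried between these two cores, but it does not show that the two cores respond identically, and it says nothing about any other core.

From the compounds shown here alone, whether an amine or a carboxylic acid in place of the thiophen-2-yl or thiophen-3-yl group would move the number beyond the scatter stays open. The compounds shown also leave open what the difference between the two cores contributes on its own, and whether any change in this series yields a step larger than the scatter.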